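Ring size at the amine on the core: compound 4

This account rests on a few compounds, and the source may have more. Where it says the series, first, only, none or still open, it means among the compounds named here.

Measured so far:
compound 1 `CC(C(=O)NCc1ccc(C(F)(F)F)nc1N(C)C)c1ccc(NS(C)(=O)=O)c(F)c1` 2390 nM
compound 2 `CCCCN(C)c1nc(C(F)(F)F)ccc1CNC(=O)C(C)c1ccc(NS(C)(=O)=O)c(F)c1` 21.3 nM
compound 3 `CC(C(=O)NCc1ccc(C(F)(F)F)nc1N1CC=CCC1)c1ccc(NS(C)(=O)=O)c(F)c1` 12.1 nM

In a functional assay on CHO-K1 cells for antagonist activity at transient receptor potential cation channel subfamily V member 1 (Homo sapiens), read by FLIPR (a higher number here means a weaker inhibitor, a lower number a stronger inhibitor), compound 3 gives the lowest number of the three, but its gap to compound 2 is within the scatter, so the two cannot be ranked. Compound 4 `CC(C(=O)NCc1ccc(C(F)(F)F)nc1N1CCCCCC1)c1ccc(NS(C)(=O)=O)c(F)c1` differs from compound 3 in one place: a group of 7 heavy atoms (6 carbon, 1 nitrogen; one seven-membered non-aromatic ring with 1 hetero atom) in place of a group of 6 heavy atoms (5 carbon, 1 nitrogen; one six-membered non-aromatic ring with 1 hetero atom), on an aromatic carbon. Among the compounds with values here, two measured steps bear on this. The step of a 200-fold lower number from compound 1 to compound 3 (2.30 log units; beyond the scatter) shows that a larger group at this position is strongly favoured over the smaller one in compound 1. The step of a 1.8-fold lower number from compound 2 to compound 3 (0.25 log units; within the scatter) shows that a chain and a ring of the same heavy-atom count give numbers within the scatter. A seven-membered ring in place of the six-membered one is therefore expected to leave this assay largely unchanged, a 1.2-fold higher number from compound 3 to compound 4 (0.09 log units; within the scatter). Compound 4 is estimated at 15 nM, range 5 nM to 50 nM.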

Compound 4, half-maximal inhibitory concentration: 25.1 nM
Beside the measured number, compound 4's estimate is 1.7-fold (0.22 log units) below it; measured number inside the range.
By their numbers in this assay, from the lowest: compounds 3, 2 and 4 (each within the scatter of the next, the first and the last beyond it); then compound 1.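

The seven-membered azepan-1-yl ring does not match the six-membered ring with its double bond (a 2.1-fold higher number from compound 3 to compound 4 (0.32 log units; beyond the scatter)), a modest step beyond the scatter, and this single change alters ring size and removes that double bond together. Against the open-chain butyl(methyl)amino group, azepan-1-yl stays within the scatter (a 1.2-fold higher number from compound 2 to compound 4 (0.07 log units; within the scatter)), while the step from dimethylamino remains large (a 95-fold lower number from compound 1 to compound 4 (1.98 log units; beyond the scatter)). No measurement shown accounts for these steps.

Going by these compounds, whether ring size or the double bond carries the step remains open, and a saturated piperidin-1-yl ring would separate the two. On these data alone, how a smaller pyrrolidin-1-yl ring would compare at this position is also open.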